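Lipophilicity notes on a quinoline ether amide series

A few compounds are considered here, and "the series" means these few. Any claim that something is new, unique, unknown or untested is made for them only; others in the source may bear on it.

Measured so far, in a physicochemical assay for lipophilicity, read by HPLC, in phosphate buffer, measured as chromatographic lipophilicity, at pH 7.4; on this read-out higher numbers stand for higher lipophilicity and lower numbers for lower lipophilicity:
compound 1 `COc1ccc2nc(C(F)(F)F)cc(OCC(=O)Nc3cc(C)cc(C)c3)c2c1` gives 7.02.
compound 2 `CCOc1ccc2nc(C(F)(F)F)cc(OCC(=O)Nc3cc(C)cc(C)c3)c2c1` gives 7.55.
compound 3 `COc1ccc2nc(C)cc(OC(C)C(=O)Nc3cc(C)cc(C)c3)c2c1` gives 5.76.

One change is seen twice in the set. From compound 1 to compound 2 it is methyl in place of hydrogen on a saturated chain carbon bound to an oxygen on an aromatic ring; the step it made in this assay is a number 0.53 log units higher from compound 1 to compound 2 (beyond the scatter). Compound 4 `CCC(Oc1cc(C)nc2ccc(OC)cc12)C(=O)Nc1cc(C)cc(C)c1` carries the same kind of change relative to compound 3: methyl in place of hydrogen on a saturated chain carbon, two bonds along the chain from a carbonyl carbon and an oxygen on an aromatic ring. The two places are not the same word for word: in the first pair the saturated chain carbon is bound to an oxygen on an aromatic ring, in the second pair it is two bonds along the chain from a carbonyl carbon and an oxygen on an aromatic ring, so the change is of the same kind and not the same.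

The cores also differ: compound 3 and compound 1 differ in more than one place, and the difference between the two cores is not broken down here. Compound 3 has the lowest of the three numbers in this assay, with compound 1 nearest and compound 2 furthest, both beyond the scatter.

Expectation for compound 4: the added methyl is expected to raise lipophilicity in this assay by a step of about a number 0.54 log units higher from compound 3 to compound 4 (beyond the scatter), beside the earlier step, because compound 1 to compound 2 moved by a number 0.53 log units higher from compound 1 to compound 2 (beyond the scatter). This rests on a single measured pair and on the two places differing, so the size is taken with some room. Compound 4 is therefore estimated at 6.3, within 5.9 to 6.7.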

Compound 4, distribution coefficient: 6.28
Estimate against measurement, compound 4: 0.02 log units above, and the stated range covers the measured number.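

Working notes on the step. In this assay, methyl in place of hydrogen on a saturated chain carbon, two bonds along the chain from a carbonyl carbon and an oxygen on an aromatic ring, gives a number 0.52 log units higher from compound 3 to compound 4 (beyond the scatter) on the core of compound 3, and this stands close in size to a number 0.53 log units higher from compound 1 to compound 2 (beyond the scatter) on the core of compound 1, where the saturated chain carbon is bound to an oxygen on an aromatic ring. This shows that, in these two pairs, a change of the same kind came with a step of like size and direction on both cores, but the two pairs differ in place as well as in core, so the effect of the core cannot be read apart from the effect of the place, and two pairs set no rule for the series. No measurement at hand bears on why the two steps match.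

Still open, on these data alone, is whether the step keeps its size when the change sits at one and the same place on both cores. Also open, as far as these compounds go, is how this assay responds when a longer chain such as propyl, or an amine or a carboxylic acid, stands on that saturated chain carbon in place of the methyl.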